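The source may hold more compounds than are shown below. What is called first, only, known or untested is meant among the compounds shown, and "the series" means these compounds.

In a functional assay on the whole organism for agonist activity, with Mus musculus as the target (a higher number here means that more compound is needed for the effect, a lower number that less compound is needed), compound 1 (`COC(=O)N(C)CC#CCN1CCCC1`) gives 3 mg/kg. Compound 2 (`CCOC(=O)N(C)CC#CCN1CCCC1`) gives > 100 mg/kg, which is a limit of this assay and not a number. Compound 3 (`CN(C)C(=O)N(C)CC#CCN1CCCC1`) carries dimethylamino in place of ethoxy on a carbonyl carbon. Among the compounds with values here, the one measured step that bears on this, an at least 33-fold higher number from compound 1 to compound 2 (1.52 log units; beyond the scatter), is large, and it is the step that produced the ethoxy now leaving. Within the data shown here, no measured step covers dimethylamino, so a return towards compound 1 is not expected on the strength of an at least 33-fold higher number from compound 1 to compound 2 (1.52 log units; beyond the scatter). The expected step, a number no higher from compound 2 to compound 3 (the limit leaves the size open), is none beyond the scatter. Compound 3 is estimated at 100 mg/kg, within an expected range from 20 mg/kg to 300 mg/kg.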

Compound 3, dose for half-maximal effect: > 10 mg/kg
Compound 3: no number, only a limit; the forecaster's own chance of this, stated with the estimate: 55%; the middle value lies beyond the limit too.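

In this assay, dimethylamino on the carbonyl carbon is a second group, after ethoxy, that does not keep the low dose of compound 1, with an at least 3.3-fold higher number from compound 1 to compound 3 (0.52 log units; beyond the scatter). So at this position both replacements of methoxy shown raise the number, and the change reaches beyond the ether side to an amine-bearing carbonyl. The values of compound 2 and compound 3 are both limits and not numbers, so the step between them cannot be read.

Where compound 3 really lies remains open. So does whether methylamino or a plain amino group on the carbonyl carbon would come back towards compound 1.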